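This account rests on a few compounds, and the source may have more. Where it says the series, first, only, none or still open, it means among the compounds named here.

Of the compounds shown here, three have been measured in a functional assay on KB cells (Homo sapiens), read by MTT assay (a lower number here means a stronger inhibitor, a higher number a weaker inhibitor), where a lower half-maximal inhibitory concentration marks the stronger inhibitor.

Compound 1 `O=c1ccn([C@@H]2O[C@H](CO)[C@](O)(C3CC3)[C@H]2O)c(=O)[nH]1`: in this assay compound 1 gives only a limit, > 350000 nM.
Compound 2 `CC#C[C@@]1(O)[C@@H](CO)O[C@@H](n2ccc(N)nc2=O)[C@@H]1O`: in this assay compound 2 gives 14600 nM.
Compound 3 `CC#C[C@@]1(O)[C@@H](CO)O[C@@H](n2ccc(=O)[nH]c2=O)[C@@H]1O`: in this assay compound 3 gives 70800 nM.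

Compound 2 holds the lowest of the two numbers; the nearest is compound 3, whose value sits a step higher, beyond the scatter. How the two cores of compound 2 and compound 3 differ is not broken down here.

Among the measured compounds shown here, the one measured step is from compound 3 to compound 1: an at least 4.9-fold higher number from compound 3 to compound 1 (0.69 log units; beyond the scatter), the change being (cyclopropyl in place of prop-1-yn-1-yl on a saturated ring carbon). Because the value of compound 1 is a limit (the limit of > 350000 nM in this assay, at which 1 of the 3 values shown sits), only the least size of that step is known.

Compound 4 `Nc1ccn([C@@H]2O[C@H](CO)[C@](O)(C3CC3)[C@H]2O)c(=O)n1`, not yet measured, carries the same change applied to compound 2: cyclopropyl in place of prop-1-yn-1-yl on a saturated ring carbon. The place of the change is the same as in the step from compound 3 to compound 1. An estimated step of a 6.8-fold higher number from compound 2 to compound 4 (0.84 log units; beyond the scatter) is expected, resting on the step of an at least 4.9-fold higher number from compound 3 to compound 1 (0.69 log units; beyond the scatter) seen for the same change. Compound 4 is thus expected to give about 100000 nM, estimated between 30000 nM and 350000 nM, with a real chance that only a limit is reported.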

Compound 4, half-maximal inhibitory concentration: > 350000 nM
Compound 4 ended at the assay's limit; the forecaster's own chance of this, stated with the estimate: 35%; at least 3.5-fold (0.54 log units) between middle value and limit.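

In this assay, the change of cyclopropyl in place of prop-1-yn-1-yl on the saturated ring carbon now gives an at least 23-fold higher number from compound 2 to compound 4 (1.37 log units; beyond the scatter), so the higher number seen on the core of compound 3 also appears on the core of compound 2. The change therefore points the same way on both cores shown, but its size on each is known only as a least size, and the two sizes cannot be set against each other: the same change on two cores in this assay, an at least 4.9-fold higher number (0.69 log units; beyond the scatter) from compound 3 to compound 1 and an at least 23-fold higher number (1.37 log units; beyond the scatter) from compound 2 to compound 4; the limit leaves it open whether they differ

Compound 1 and compound 4 both stop at the limit of the assay, so this pair of steps shows the direction of the change on two cores only and gives no true size for it on either, nor does it say how the change would behave on any other core: the limit of > 350000 nM in this assay, at which 2 of the 4 values shown sit.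

The compounds shown leave open whether a propyl chain, which has the same number of carbons as the prop-1-yn-1-yl group but no triple bond, would read closer to compound 2 or to compound 4 on this ring carbon. Also open, as far as these compounds go, is how a longer alkyne chain or an amine at the same place would read in this assay.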